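The compounds below may be only part of what the source reports. "The series", "measured", "known", "first", "only" and "open" are said of these compounds alone.

Measured so far in a functional assay on SK-BR-3 cells (Homo sapiens) for antiproliferative activity, read by MTT assay, with a stated time of 72 h; a lower number here means a stronger inhibitor, a higher number a weaker inhibitor:

Compound 1 `C/C=C1/[C@H](O[C@@H]2O[C@H](CO)[C@@H](O)[C@H](O)[C@H]2O)OC=C(C(=O)OC)[C@H]1CC(=O)OCc1ccco1`: > 15000 nM
Compound 2 `C#CCOC(=O)C[C@@H]1C(C(=O)OC)=CO[C@@H](O[C@@H]2O[C@H](COC(C)=O)[C@@H](OC(C)=O)[C@H](OC(C)=O)[C@H]2OC(C)=O)/C1=C/C`: > 15000 nM
Compound 3 `C/C=C1/[C@H](O[C@@H]2O[C@H](CO)[C@@H](O)[C@H](O)[C@H]2O)OC=C(C(=O)OC)[C@H]1CC(=O)OCC`: > 15000 nM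

Compound 2 gives > 15000 nM, which is a limit of the assay and not a number. The same holds across the set, as the limit of > 15000 nM in this assay, at which 3 of the 3 values shown sit, shows.

Compound 4 `C/C=C1/[C@H](O[C@@H]2O[C@H](COC(C)=O)[C@@H](OC(C)=O)[C@H](OC(C)=O)[C@H]2OC(C)=O)OC=C(C(=O)OC)[C@H]1CC(=O)OC` differs from compound 2 by hydrogen in place of ethynyl on a saturated chain carbon bound to an oxygen next to a carbonyl group. In words, this is hydrogen in place of ethynyl on a saturated chain carbon bound to an oxygen next to a carbonyl group, which also reads as propargyloxycarbonyl to methoxycarbonyl.

Among the compounds with values here, one measured step bears on this place: methyl in place of furan-2-yl, a step that the two limits leave unreadable from compound 1 to compound 3. That step has no readable size, so it offers no evidence of a change here. No step beyond the scatter is therefore expected in this assay, and a report at the limit is the likeliest outcome.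

For compound 4 the estimated value is 20000 nM, with an expected range from 9000 nM to 50000 nM. This estimate means an expected step that the limit leaves unreadable from compound 2 to compound 4.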

Compound 4, half-maximal inhibitory concentration: > 15000 nM
Compound 4 was reported as a limit; the forecaster's own chance of this, stated with the estimate: 80%; the middle value lies beyond the limit too.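

Compound 4 gives > 15000 nM, a limit of the assay and not a number, so no step can be read between compound 2 and compound 4, and the set remains at a single limit: the limit of > 15000 nM in this assay, at which 4 of the 4 values shown sit.

The compounds shown leave open how strongly any of them inhibits in this assay, and whether any change to the ester group alters that.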